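Moving the chain amine into the chain: compound 3 to 4

The compounds below may be only part of what the source reports. "The series", "measured", "known", "first", "only" and "open" are said of these compounds alone.

Measured so far in a functional assay for agonist activity at G protein-coupled receptor 88 (Homo sapiens), read by HTRF and cAMP accumulation; a lower number here means that less compound is needed, a higher number that more compound is needed for the effect:
- compound 1 `CC(C)CCCN(C(=O)[C@@H]1C[C@H]1c1ccccc1)c1ccc(-c2ccccc2)cc1`: > 100 nM
- compound 2 `CC[C@@H](C)[C@H](N)CN(C(=O)[C@@H]1C[C@H]1c1ccccc1)c1ccc(-c2ccccc2)cc1`: 1.4 nM
- compound 3 `CC(C)C[C@H](N)CCN(C(=O)[C@@H]1C[C@H]1c1ccccc1)c1ccc(-c2ccccc2)cc1`: 3 nM

Compound 3 stands highest among the two numbers, with compound 2 the nearest, as a 2.1-fold higher number from compound 2 to compound 3 (0.33 log units; beyond the scatter) shows. The value of compound 1 is a limit of this assay, not a number. Relative to compound 1, both amine-bearing chains gave large steps: an at least 71-fold lower number from compound 1 to compound 2 (1.85 log units; beyond the scatter) and an at least 33-fold lower number from compound 1 to compound 3 (1.52 log units; beyond the scatter).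

Compound 4 `CCC(C)CNCCN(C(=O)[C@@H]1C[C@H]1c1ccccc1)c1ccc(-c2ccccc2)cc1` differs from compound 3 by (2-methylbutyl)amino in place of 1-amino-3-methylbutyl on a saturated chain carbon, two bonds along the chain from an amide-type nitrogen. The nitrogen thus moves from a stereocentre on the chain into the chain itself, and the stereocentre is lost. Going by the values given here, no measured step tests this move directly; the steps from compound 1 only show that adding a chain nitrogen lowers the number strongly, and the step between compound 2 and compound 3 shows that its placement matters modestly. Compound 4 keeps a chain nitrogen, so a number well under the limit of compound 1 is expected, but some loss against compound 3 is plausible: the expected step is a 5.0-fold higher number from compound 3 to compound 4 (0.70 log units; beyond the scatter). Compound 4 is therefore estimated at 15 nM, ranging from 3 nM to 150 nM.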

Compound 4, half-maximal effective concentration: 4.7 nM
The estimate for compound 4 lay 3.2-fold (0.50 log units) above the measured number; low and high end bracket the measured number.
By their numbers in this assay, from the lowest: compound 2; then compounds 3 and 4 (each within the scatter of the next). At a limit, above all of these: compound 1.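

In this assay, moving the nitrogen off the stereocentre of 1-amino-3-methylbutyl and into the chain as (2-methylbutyl)amino gives a 1.6-fold higher number from compound 3 to compound 4 (0.19 log units; within the scatter), so a defined stereocentre on this chain is not needed for a low number. The new chain keeps the large gain over the chain without nitrogen, with an at least 21-fold lower number from compound 1 to compound 4 (1.32 log units; beyond the scatter), while the gap to the shorter amine-bearing chain remains modest, with a 3.4-fold higher number from compound 2 to compound 4 (0.53 log units; beyond the scatter). The value of compound 1 is a limit, so the first of these steps has only a lower bound: the limit of > 100 nM in this assay, at which 1 of the 4 values shown sits.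

On these data alone, whether a tertiary amine at this place keeps the number low remains open, as does the effect of a hydroxyl or a carboxylic acid in place of the chain amine. A longer chain on the amine nitrogen, such as hexyl, is equally untested in the compounds shown.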